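This account rests on a few compounds, and the source may have more. Where it says the series, first, only, none or still open, it means among the compounds named here.

Compound 3 `COc1ccc(C(=O)Nc2cccnc2)cc1OC1CCCC1` stands at the higher end of the numbers gathered so far: in an assay on isolated protein for inhibition of phosphodiesterase 4A (Sus scrofa) (on this read-out higher numbers stand for weaker inhibition and lower numbers for stronger inhibition), compound 3 gives 550 nM. Its nearest neighbour is compound 2 `COc1ccc(C(=O)Nc2c(C)cccc2Cl)cc1OC1CCCC1`, which in this assay gives 100 nM, so that a 5.5-fold higher number from compound 2 to compound 3 (0.74 log units; beyond the scatter). Compound 1 `COc1ccc(C(=O)Nc2cccc(Cl)c2Cl)cc1OC1CCCC1` reaches only a limit of the assay, giving > 200000 nM in this assay. The two steps away from that limit are an at least 2000-fold lower number from compound 1 to compound 2 (3.30 log units; beyond the scatter) and an at least 360-fold lower number from compound 1 to compound 3 (2.56 log units; beyond the scatter); both rest on (the limit of > 200000 nM in this assay, at which 1 of the 3 values shown sits), so their exact size is open. Compound 4 `COc1ccc(C(=O)Nc2c(Br)cncc2Br)cc1OC1CCCC1` has not yet been measured and differs from compound 3 by 3,5-dibromopyridin-4-yl in place of pyridin-3-yl on an amide-type nitrogen. The measured steps that bear on it are those exchanging the group on the amide nitrogen: the substituted ring of compound 2 gave the lowest number, while the substituted ring of compound 1 sat at the limit, so substitution alone does not settle the direction. Because compound 2 with its substituted ring reached 100 nM, a lower number than compound 3 is expected for compound 4. Compound 4 is estimated at 5 nM, between 1 nM and 30 nM. The expected step would be a 110-fold lower number from compound 3 to compound 4 (2.04 log units; beyond the scatter).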

Compound 4, half-maximal inhibitory concentration: 7 nM
Compound 4: middle estimate off by 1.4-fold (0.15 log units), on the low side; low and high end bracket the measured number.
By their numbers in this assay, from the lowest: compound 4; then compound 2; then compound 3. At a limit, above all of these: compound 1.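

In this assay, a pyridine ring on an amide-type nitrogen is not tied to the level of compound 3: 3,5-dibromopyridin-4-yl in place of pyridin-3-yl gives a 79-fold lower number from compound 3 to compound 4 (1.90 log units; beyond the scatter). The new group also passes the 2-chloro-6-methylphenyl group, with a 14-fold lower number from compound 2 to compound 4 (1.15 log units; beyond the scatter), so the lowest number shown now belongs to a pyridine ring carrying two bromine atoms. Compound 1 remains at a limit of the assay, which leaves the exact size of an at least 28000-fold lower number from compound 1 to compound 4 (4.45 log units; beyond the scatter) open: the limit of > 200000 nM in this assay, at which 1 of the 4 values shown sits.

On these data alone, the change from compound 3 to compound 4 alters the ring attachment and adds both bromine atoms at once, so the share of each stays unknown, and a 3,5-dichloropyridin-4-yl group could help to test the role of the halogen. The shared core stays constant throughout, leaving open how a smaller ether, such as ethoxy, would fare in place of its cyclopentyl ether.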